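The source may report more compounds than this note shows. Statements on the series, on what has been measured and on what is new or still open speak of the compounds shown alone.

Measured compounds in an in vitro assay on 293-EBNA cells for binding affinity to corticotropin-releasing factor receptor 1 (Homo sapiens); on this read-out lower numbers stand for stronger inhibition and higher numbers for weaker inhibition:
compound 1 `CCCCN(CC)c1nc(C)nc2c1nnn2-c1ccc(C(C)C)cc1Br` gives 7.5 nM
compound 2 `COCCNc1nc(C)nc2c1nnn2-c1ccc(C(C)C)cc1Br` gives 242 nM
compound 3 `CCCCNc1nc(C)nc2c1nnn2-c1ccc(C(C)C)cc1Br` gives 69.6 nM

Compound 1 has the lowest number of the three in this assay. Its nearest neighbour is compound 3, with a 9.3-fold higher number from compound 1 to compound 3 (0.97 log units; beyond the scatter); the furthest is compound 2, with a 32-fold higher number from compound 1 to compound 2 (1.51 log units; beyond the scatter). Between compound 2 and compound 3 the step is a 3.5-fold lower number from compound 2 to compound 3 (0.54 log units; beyond the scatter).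

Compound 4 `CCCCN(CC)c1nc(C)nc2c1nnn2-c1ccc(S(C)(=O)=O)cc1Br` differs from compound 1 in one place: methylsulfonyl in place of isopropyl on an aromatic carbon. Every measured step in this series changes the amino substituent on the shared core; none touches the six-membered aromatic ring of carbon only. The measured steps therefore do not bear directly on this change, and they set no size for it. With the change sitting on a part of the molecule the series has not varied, the direction is open; the working expectation for compound 4 is a step toward a higher number of modest size, an 8.0-fold higher number from compound 1 to compound 4 (0.90 log units; beyond the scatter), with a wide range. Compound 4 is estimated at 60 nM, between 10 nM and 400 nM.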

Compound 4, inhibition constant: 100 nM
Estimate against measurement, compound 4: 1.7-fold (0.22 log units) below; low and high end bracket the measured number.
By their numbers in this assay, from the lowest: compound 1; then compounds 3 and 4 (each within the scatter of the next); then compound 2.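

In this assay, going by these compounds alone, methylsulfonyl in place of isopropyl gives a 13-fold higher number from compound 1 to compound 4 (1.12 log units; beyond the scatter), the first evidence that this aromatic carbon, para to a large group and meta to a bromo group, affects the read-out and not only the amino substituent does. Within the data shown here, compound 4 keeps the butyl(ethyl)amino group of compound 1, so this step comes from the one exchange, in which a group with hydrogen-bond acceptors replaces one with none. No measurement at hand accounts for the size or direction of the step.

Going by these compounds, with a single replacement at this carbon, it remains open how tert-butyl, dimethylamino or methylsulfinyl would read there. Also open, on these data alone, is whether methylsulfonyl would give a similar step on the butylamino side chain of compound 3.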